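Fluoro to bromo on the para-substituted phenyl ring

The source may hold more compounds than are shown below. What is called first, only, known or untested is meant among the compounds shown, and "the series" means these compounds.

Measured compounds in a functional assay on SNB-75 cells (Homo sapiens) for inhibition, read by sulforhodamine B assay, with a stated time of 48 h, tested at 10 uM; a lower number here means less inhibition, a higher number more inhibition at the concentration tested (going by the name of the read-out):
compound 1 `COc1ccc(-c2cn3ccnc3c(-c3ccc4ncn(C5CCCCC5)c4c3)n2)cc1` gives -26.3%
compound 2 `Fc1ccc(-c2cn3ccnc3c(-c3ccc4ncn(C5CCCCC5)c4c3)n2)cc1` gives 21%

Compound 2 stands highest of the two measured numbers; the step of a number 47.3 percentage points higher from compound 1 to compound 2 (beyond the scatter) lies beyond the scatter. Compound 3 `Brc1ccc(-c2cn3ccnc3c(-c3ccc4ncn(C5CCCCC5)c4c3)n2)cc1` differs from compound 2 by bromo in place of fluoro on an aromatic carbon. Going by the values given here, no measured step changes one halogen for another, so the step from compound 1 to compound 2 bears on it only distantly, and no step beyond the scatter is expected for compound 3, though the number is estimated slightly higher: a number 5 percentage points higher from compound 2 to compound 3 (within the scatter). Compound 3 is therefore expected to give about 26%, within 2% to 50%.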

Compound 3, a percentage reported as inhibition, at one concentration (the size of the read-out at that concentration, not a potency): 34.6%
Estimate against measurement, compound 3: 8.6 percentage points below, and the stated range covers the measured number.
By their numbers in this assay, from the lowest: compound 1; then compound 2; then compound 3.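

In this assay, the choice of halogen on the phenyl ring counts for something: the change from 4-fluorophenyl to 4-bromophenyl gives a number 13.6 percentage points higher from compound 2 to compound 3 (beyond the scatter), a modest step beyond the scatter. Bromo in place of methoxy gives a number 60.9 percentage points higher from compound 1 to compound 3 (beyond the scatter), a larger step than fluoro gave, so at this position the bromo compound now stands furthest from the methoxy compound. Nothing available explains this order.
Whether chloro, which is absent from the compounds shown, would fall between fluoro and bromo stays open. So does how an amine or a carboxylic acid at this position would read.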